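Iodo for ethynyl on a fused two-ring core

The compounds below may be only part of what the source reports. "The series", "measured", "known", "first", "only" and "open" are said of these compounds alone.

Measured so far in a functional assay on NCI-H522 cells (Homo sapiens) for cytotoxicity, with a stated time of 3 days; on this read-out lower numbers stand for stronger inhibition and higher numbers for weaker inhibition:
- compound 1 `C#Cc1ncccn1` gives > 40000 nM.
- compound 2 `C#Cc1nc2ccccc2n1C` gives 8140 nM.
- compound 3 `Ic1nc2ccccc2o1` gives 11700 nM.

For compound 1 the value of > 40000 nM is a limit of this assay, not a number; the limit is the limit of > 40000 nM in this assay, at which 1 of the 3 values shown sits. Of the two numbers, compound 2 has the lowest, and its nearest neighbour is compound 3, whose number lies within the scatter of it, so the two cannot be told apart.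

The step considered leads from compound 2 to compound 4 `Cn1c(I)nc2ccccc21`, which has not yet been measured in this assay. The change is iodo in place of ethynyl on an aromatic carbon.

In this assay compound 3 also carries an iodo group, on a different core, and its number sits close to that of compound 2. A small step is therefore expected for compound 4 in this assay, if any beyond the scatter, with the estimate a 1.5-fold higher number from compound 2 to compound 4 (0.17 log units; within the scatter). Compound 4 is expected to give about 12000 nM, between 4000 nM and 40000 nM.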

Compound 4, half-maximal inhibitory concentration: 1020 nM
Compound 4: middle estimate off by 12-fold (1.07 log units), on the high side; measured number outside the range, below it.
By their numbers in this assay, from the lowest: compound 4; then compounds 2 and 3 (each within the scatter of the next). At a limit, above all of these: compound 1.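

In this assay, putting iodo in place of ethynyl on the aromatic carbon between two ring nitrogen atoms gives an 8.0-fold lower number from compound 2 to compound 4 (0.90 log units; beyond the scatter). Compound 3 also carries iodo, but on a different core, so it could not show this; with the core held constant, the group at this position clearly changes the number. Nothing measured here explains why the number falls.

Still open, going by these compounds, is whether another group at this position, such as chloro, bromo or an amine, would give a similar number or a lower one.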